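The source may hold more compounds than are shown below. What is called first, only, known or untested is meant among the compounds shown, and "the series" means these compounds.

Measured compounds:
compound 1 `COc1cc(C)cc(-c2c(-c3ccnc(-c4ccc(C(C)=O)cc4)c3)cnn2CC#N)c1` — -55%
compound 2 `COc1cc(C)cc(-c2nn(CC#N)cc2-c2ccc(-c3cccc(C(C)=O)c3)nc2)c1` — -53%

In a functional assay on MDA-MB-468 cells (Homo sapiens) for cytotoxicity, read by sulforhodamine B assay, with a stated time of 48 h, tested at 10 uM (a lower number here means a stronger effect, a higher number a weaker effect of the compound at the concentration tested), compound 1 gives -55%. Its number is the lower of the two measured, and compound 2 at -53% lies within the scatter of it, so the two cannot be ordered. Compound 3 `COc1cc(C)cc(-c2c(-c3ccnc(-c4ccc(N(C)C)cc4)c3)cnn2CC#N)c1` is not yet measured. It differs from compound 1 by dimethylamino in place of acetyl on an aromatic carbon. Within the data shown here, no measured pair shows this change, so no step in this assay can guide the expectation. Compound 3 is expected to give -35% (range -70% to 0%). The expected step of a number 20 percentage points higher from compound 1 to compound 3 (beyond the scatter) is a modest weakening, hardly beyond the scatter.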

Compound 3, a percentage reported as activity, at one concentration (the size of the read-out at that concentration, not a potency): -59%
Compound 3: middle estimate off by 24 percentage points, on the high side; the range from low to high includes it.
By their numbers in this assay, from the lowest: compounds 3, 1 and 2 (each within the scatter of the next).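

In this assay, exchanging 4-acetylphenyl for 4-(dimethylamino)phenyl gives a number 4 percentage points lower from compound 1 to compound 3 (within the scatter), so the two compounds cannot be told apart. The acetyl carbonyl is therefore not required for the effect at this place, on an aromatic carbon para to a large group, at the one concentration tested. Nothing available bears on why the two groups read alike.

Going by these compounds, whether a carboxylic acid, a primary amine or a longer chain at this place would give a similar reading remains open. So does how compound 1 and compound 3 compare at any other concentration.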